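Compound 4: thiazole swap on the compound 1 side chain

The source may report more compounds than this note shows. Statements on the series, on what has been measured and on what is new or still open speak of the compounds shown alone.

Measured in an ADME assay on Huh-7 cells (Homo sapiens) for cytotoxicity, read by MTT assay, with a stated time of 96 h (a lower number here means that less compound is tolerated, a higher number that more compound is tolerated), so far
- compound 1 `COc1cc(NCc2ccc(C)o2)ccc1-c1cnco1`: 63400 nM
- compound 2 `COc1cc(NCc2ccc(Cl)s2)ccc1-c1cnco1`: 43200 nM
- compound 3 `COc1ccc(-c2cnco2)cc1NCc1cccs1`: > 100000 nM (a limit)

Compound 1 has one other exact number to compare with, and the two cannot be separated: a 1.5-fold lower number from compound 1 to compound 2 (0.17 log units; within the scatter). Compound 3 gives only a limit, > 100000 nM, a position shared by the limit of > 100000 nM in this assay, at which 1 of the 3 values shown sits.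

Compound 4 `COc1cc(NCc2cncs2)ccc1-c1cnco1` carries 1,3-thiazol-5-yl in place of 5-methylfuran-2-yl on a saturated chain carbon bound to a nitrogen on an aromatic ring. The one measured replacement of 5-methylfuran-2-yl, by 5-chlorothiophen-2-yl, stayed within the scatter, so no step beyond the scatter is expected here. The expected step is a 1.1-fold higher number from compound 1 to compound 4 (0.04 log units; within the scatter). For compound 4 the estimated value is 70000 nM, with an expected range of 35000 nM to 100000 nM.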

Compound 4, half-maximal cytotoxic concentration: 68900 nM
For compound 4 the middle estimate is 1.0-fold (0.01 log units) above the measured one, and the stated range covers the measured number.
By their numbers in this assay, from the lowest: compounds 2, 1 and 4 (each within the scatter of the next). At a limit, above all of these: compound 3.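

A further replacement of 5-methylfuran-2-yl, by 1,3-thiazol-5-yl, also stays within the scatter (a 1.1-fold higher number from compound 1 to compound 4 (0.04 log units; within the scatter)). The same holds against the 5-chlorothiophen-2-yl group (a 1.6-fold higher number from compound 2 to compound 4 (0.20 log units; within the scatter)), so in this assay these three five-membered aromatic rings, with 1 or 2 hetero atoms, cannot be told apart at this place. Nothing at hand bears on a cause for this.

From the compounds shown here alone, whether a carboxylic acid or a dimethylamino group in place of 5-methylfuran-2-yl, or a longer chain at this place, gives a step beyond the scatter stays open.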